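Isobutyl thiourea analogue of a pyridazinone: an estimate

The source may report more compounds than this note shows. Statements on the series, on what has been measured and on what is new or still open speak of the compounds shown alone.

Measured so far:
- compound 1, `CCC/N=C(/NC#N)NCCCCn1nc(-c2ccccc2)ccc1=O`: 26.3% in a functional assay on the whole organism with Rattus norvegicus as the target, at a dose of 100 mg/kg; a higher number here means more inhibition at the dose given (going by the name of the read-out), a lower number less inhibition
- compound 2, `C/N=C(\S)N(C)CCCCn1nc(-c2ccccc2)ccc1=O`: 17.5%

Both compounds share a core carrying a phenyl-substituted ring joined through a four-carbon chain to a terminal group. In this assay compound 2 gives the lower of the two numbers, yet the gap to compound 1 lies within the scatter, so the two cannot be told apart. Compound 3, `CC(C)C/N=C(\S)NCCCCn1nc(-c2ccccc2)ccc1=O`, has not yet been measured. Compared with compound 2, it carries a group of 8 heavy atoms (5 carbon, 2 nitrogen, 1 sulfur; no ring) in place of a group of 6 heavy atoms (3 carbon, 2 nitrogen, 1 sulfur; no ring), on a saturated chain carbon, four bonds along the chain from an aromatic nitrogen. Going by the values given here, no step between measured compounds is known, so nothing here shows how such a change shifts the read-out in this assay. The expectation is therefore a step from compound 2 of a number 4.5 percentage points higher from compound 2 to compound 3 (within the scatter), not beyond the scatter in either direction. Compound 3 is estimated to give 22% in this assay, with a range from 8% to 38%.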

Compound 3, a percentage reported as inhibition, in the whole organism at one dose (the size of the read-out at that dose, not a potency): 35.8%
Compound 3: middle estimate off by 13.8 percentage points, on the low side, within the range that was stated.
By their numbers in this assay, from the lowest: compounds 2, 1 and 3 (each within the scatter of the next, the first and the last beyond it).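

In this assay, going by these compounds alone, placing the group of 8 heavy atoms in place of the group of 6 heavy atoms, on a saturated chain carbon, four bonds along the chain from an aromatic nitrogen, gives a number 18.3 percentage points higher from compound 2 to compound 3 (beyond the scatter), the first change here that stands clear of the noise. The comparison with the remaining compound is less telling: the group of 8 heavy atoms containing sulfur, in place of the group of 8 heavy atoms containing only carbon and nitrogen, on an amine nitrogen, gives a number 9.5 percentage points higher from compound 1 to compound 3 (within the scatter), so these two cannot be told apart. No measurement here accounts for either result.

The larger group and the added hydrogen-bond donor arrive together, so the step cannot be assigned to one or the other. On these data alone, whether a thiourea carrying a cyclohexyl group, or a longer chain between the shared core and the thiourea, would follow the same trend remains open.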